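Chain end variation on the shared core: aldehyde analogue

The source may report more compounds than this note shows. Statements on the series, on what has been measured and on what is new or still open speak of the compounds shown alone.

In an assay on COS-7 cells for displacement of a labelled ligand from Endothelin receptor type B (Sus scrofa) (a lower number here means a stronger inhibitor, a higher number a weaker inhibitor), compound 3 `COc1cccc(Sc2c(NS(=O)(=O)c3ccc(C(C)(C)C)cc3)noc2CCCC(N)=O)c1` gives 240 nM. Compound 2 `COc1cccc(Sc2c(NS(=O)(=O)c3ccc(C(C)(C)C)cc3)noc2C)c1` gives 300 nM in this assay and compound 1 `COC(=O)CCCc1onc(NS(=O)(=O)c2ccc(C(C)(C)C)cc2)c1Sc1cccc(OC)c1` gives 310 nM. Compound 3 thus shows the lowest of the three numbers, but both gaps to its neighbours, a 1.3-fold lower number from compound 2 to compound 3 (0.10 log units; within the scatter) and a 1.3-fold lower number from compound 1 to compound 3 (0.11 log units; within the scatter), lie within the scatter, so the three compounds cannot be ordered.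

Compound 4 `COc1cccc(Sc2c(NS(=O)(=O)c3ccc(C(C)(C)C)cc3)noc2CCC=O)c1` differs from compound 3 in one place: formyl in place of carbamoylmethyl on a saturated chain carbon, two bonds along the chain from an aromatic carbon. The chain on this carbon has already been varied among the measured compounds. The step of a 1.0-fold lower number from compound 1 to compound 2 (0.01 log units; within the scatter), which removes the whole 2-(methoxycarbonyl)ethyl chain, and the step of a 1.3-fold lower number from compound 2 to compound 3 (0.10 log units; within the scatter), which adds the 2-carbamoylethyl chain, both stay within the scatter, as does the exchange of methoxy for amino on the carbonyl carbon in a 1.3-fold lower number from compound 1 to compound 3 (0.11 log units; within the scatter). Every change at this end of the chain so far has left the number where it was, so the shortened chain ending in formyl is expected to do the same, with a 1.2-fold higher number from compound 3 to compound 4 (0.07 log units; within the scatter) anticipated to stay within the scatter.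

Compound 4 is therefore estimated at 280 nM in this assay, with a range of 120 nM to 650 nM.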

Compound 4, half-maximal inhibitory concentration: 500 nM
Estimate against measurement, compound 4: 1.8-fold (0.25 log units) below; low and high end bracket the measured number.
By their numbers in this assay, from the lowest: compounds 3, 2, 1 and 4 (each within the scatter of the next, the first and the last beyond it).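

In this assay, within the data shown here, this is the first change to pass the scatter: a 2.1-fold higher number from compound 3 to compound 4 (0.32 log units; beyond the scatter) is a modest step, with formyl in place of carbamoylmethyl on a saturated chain carbon, two bonds along the chain from an aromatic carbon. Among these compounds, the other two comparisons do not pass it, as a 1.7-fold higher number from compound 2 to compound 4 (0.22 log units; within the scatter) and a 1.6-fold higher number from compound 1 to compound 4 (0.21 log units; within the scatter) both stay within the scatter, so the position responds in only one of the three comparisons. No measured evidence available here bears on this step.

Compound 4 differs from compound 3 in both chain length and end group, so the compounds shown do not separate the two. Also open, going by these compounds, is how a carboxylic acid, an amine or a longer chain ending in formyl would read at this position.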